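The source may hold more compounds than are shown below. What is called first, only, known or untested is meant among the compounds shown, and "the series" means these compounds.

Of the compounds shown here, three have been measured and one has not. Compound 1 `COc1cc(CNc2ncnc3c2ncn3C2CCCCO2)cc(OC)c1` and compound 2 `COc1cc(CNc2ncnc3c2ncn3C2CCCCO2)cc(OC)c1OC` are built on one core and differ in a single change: methoxy in place of hydrogen on an aromatic carbon. Compound 3 `COc1ccc(CNc2ncnc3c2ncn3C2CCCO2)c(OC)c1` is built on another core; the difference between the two cores is not broken down here. Compound 4 `COc1ccc(CNc2ncnc3c2ncn3C2CCCO2)c(OC)c1OC` is the one still to be measured, and it differs from compound 3 by methoxy in place of hydrogen on an aromatic carbon. For the measured compounds named here, the change from compound 3 to compound 4 is the same kind of change as the one from compound 1 to compound 2, but not the same, since in compound 2 the entering methoxy sits para to a large group, while in compound 4 it sits meta to a large group.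

In an ADME assay on BJ cells (Homo sapiens) for cytotoxicity, read by MTT assay, with a stated time of 72 h (on this read-out higher numbers stand for weaker inhibition and lower numbers for stronger inhibition), compound 1 gives > 100000 nM, which is a limit of the assay and not a number. In this assay compound 2 gives > 100000 nM, again a limit. In this assay compound 3 gives > 100000 nM, also a limit. The step that the two limits leave unreadable from compound 1 to compound 2 cannot be read because of the limit of > 100000 nM in this assay, at which 3 of the 3 values shown sit.

For compound 4 the step that the limit leaves unreadable from compound 3 to compound 4 is expected to be just as unreadable. That expectation rests on compound 3, whose result in this assay is the limit > 100000 nM. Compound 4 is therefore estimated to give about 150000 nM in this assay, somewhere between 80000 nM and 500000 nM, most likely reported only as a limit.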

Compound 4, half-maximal inhibitory concentration: > 100000 nM
Compound 4: only a limit was reported; the forecaster's own chance of this, stated with the estimate: 90%; the middle value does not contradict the limit.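

In this assay compound 4 gives > 100000 nM, which is a limit of the assay and not a number. No size can be read for the change from compound 3 to compound 4, because the result on each side is a limit: the limit of > 100000 nM in this assay, at which 4 of the 4 values shown sit.

The compounds shown leave open whether methoxy in place of hydrogen on an aromatic carbon changes the result in this assay at all, in either pair.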